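The source may hold more compounds than are shown below. What is called first, only, known or untested is meant among the compounds shown, and "the series" means these compounds.

In a functional assay (trachea) with Cavia porcellus as the target (on this read-out lower numbers stand for stronger inhibition and higher numbers for weaker inhibition), three compounds with a shared core have been measured: compound 1 `CCn1nc(-c2cccnc2)c2ccccc2c1=O` gives 1320 nM, compound 2 `CCCn1nc(-c2cccnc2)c2ccccc2c1=O` gives 3160 nM and compound 3 `CC(C)=CCn1nc(-c2cccnc2)c2ccccc2c1=O` gives 1380 nM. Compound 3 thus stands level with compound 1 and clear of compound 2. The data show a 1.0-fold higher number from compound 1 to compound 3 (0.02 log units; within the scatter) and a 2.3-fold lower number from compound 2 to compound 3 (0.36 log units; beyond the scatter).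

Compound 4 `O=c1c2ccccc2c(-c2cccnc2)nn1Cc1ccccc1` has phenyl in place of 2-methylprop-1-en-1-yl on a saturated chain carbon bound to an aromatic nitrogen. The measured steps at this chain are small, and the other one is a 2.4-fold higher number from compound 1 to compound 2 (0.38 log units; beyond the scatter). None of them brings a ring into this place, so they guide the expectation only loosely. Even so, the modest size of all these steps, including the one to compound 3 shown above, suggests no step beyond the scatter in this assay, with a wide margin either way. The expected step is a 1.1-fold higher number from compound 3 to compound 4 (0.04 log units; within the scatter). For compound 4, the estimated value is 1500 nM, within an expected range of 550 nM to 4000 nM.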

Compound 4, half-maximal inhibitory concentration: 2450 nM
Beside the measured number, compound 4's estimate is 1.6-fold (0.21 log units) below it; the measured number falls inside the stated range.
By their numbers in this assay, from the lowest: compounds 1, 3, 4 and 2 (each within the scatter of the next, the first and the last beyond it).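

Compound 4 brings the first ring to the saturated chain carbon bound to an aromatic nitrogen, and in this assay this change stays within the scatter against all three earlier compounds: a 1.8-fold higher number from compound 3 to compound 4 (0.25 log units; within the scatter), a 1.9-fold higher number from compound 1 to compound 4 (0.27 log units; within the scatter) and a 1.3-fold lower number from compound 2 to compound 4 (0.11 log units; within the scatter). The position therefore accepts phenyl without a readable change, and compound 4 cannot be placed on either side of compound 1 or compound 2, even though a 2.4-fold higher number from compound 1 to compound 2 (0.38 log units; beyond the scatter) lies beyond the scatter. No measurement offered here bears on why this is so.

On these data alone, it remains open whether a pyridine ring, an amine or a carboxylic acid at this place would give a step beyond the scatter. A longer chain carrying the phenyl ring, or a substituted phenyl ring, also remains untested in the compounds shown.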